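Aryl swap on the shared core: compound 2 to compound 4

A few compounds are considered here, and "the series" means these few. Any claim that something is new, unique, unknown or untested is made for them only; others in the source may bear on it.

Working notes on a small series measured in a functional assay on MOLT-4 cells (Homo sapiens) for cytotoxicity, read by CCK-8 assay, with a stated time of 72 h; on this read-out higher numbers stand for weaker inhibition and lower numbers for stronger inhibition. Compound 1 `C=CCn1c(=O)/c(=C\c2cccc(F)c2)[nH]c(=O)/c1=C\c1ccccc1OC` gives 6500 nM. Among the compounds with values here, compound 2 `C=CCn1c(=O)/c(=C\c2cc(F)ccc2C)[nH]c(=O)/c1=C\c1ccccc1OC` gives 3800 nM, which is the lowest of the two numbers so far; its nearest neighbour is compound 1, and the step of a 1.7-fold lower number from compound 1 to compound 2 (0.23 log units; within the scatter). Compound 3 `COc1ccccc1/C=c1\c(=O)[nH]/c(=C/c2ccccc2Cl)c(=O)n1C` is recorded in this assay as "not determined" (no result reported), so no number is available for it.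

Compound 4 `C=CCn1c(=O)/c(=C\c2cccc(Br)c2)[nH]c(=O)/c1=C\c1ccccc1OC` has not yet been measured. The change from compound 2 is 3-bromophenyl in place of 5-fluoro-2-methylphenyl on a double-bonded chain carbon bound to an aromatic carbon. Within the data shown here, the only measured step, a 1.7-fold lower number from compound 1 to compound 2 (0.23 log units; within the scatter), concerns a methyl in place of hydrogen on an aromatic carbon and does not involve a bromine; it bears on the present change only in that it shows the series moving little in this assay across a change of the same ring. Compound 1 carries 3-fluorophenyl on the same chain carbon and gives 6500 nM, within the scatter of compound 2. For compound 4 the step of a 1.3-fold higher number from compound 2 to compound 4 (0.12 log units; within the scatter) is therefore expected to stay within the scatter. Compound 4 is estimated at 5000 nM, with a range from 2000 nM to 13000 nM.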

Compound 4, half-maximal inhibitory concentration: 5000 nM
Beside the measured number, compound 4's estimate shows no gap at the digits printed; low and high end bracket the measured number.
By their numbers in this assay, from the lowest: compounds 2, 4 and 1 (each within the scatter of the next).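

In this assay, 3-bromophenyl in place of 5-fluoro-2-methylphenyl on a double-bonded chain carbon bound to an aromatic carbon gives a 1.3-fold higher number from compound 2 to compound 4 (0.12 log units; within the scatter), so exchanging this whole aryl group leaves the two compounds within the scatter. Bromo in place of fluoro on an aromatic carbon gives a 1.3-fold lower number from compound 1 to compound 4 (0.11 log units; within the scatter), which adds a halogen exchange at one ring carbon to the methyl step already seen, and it also stays within the scatter. No supporting evidence bears on this result, so the closeness of compounds 1, 2 and 4 remains an observation without an explanation.

The compounds shown carry only halogen and methyl groups on this aryl ring, so they leave open whether any group on it would separate from these three. An amine, a carboxylic acid or a longer chain on the same ring would be the next test of how far this position stays flat.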